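Working notes: phenyl enters the series at compound 3

This account rests on a few compounds, and the source may have more. Where it says the series, first, only, none or still open, it means among the compounds named here.

Values in a toxicity assay on THP-1 cells (Homo sapiens) for cytotoxicity; a lower number here means that less compound is needed, a higher number that more compound is needed for the effect:
- compound 1 `Cc1n[nH]c(-c2ncc3c(N(C)C)ccnc3c2O)n1`: > 50100 nM (a limit)
- compound 2 `Cc1n[nH]c(-c2ncc3c(N4CCCCS4(=O)=O)ccnc3c2O)n1`: > 50100 nM (a limit)

Neither entry is a number. In this assay compound 2 gives > 50100 nM, and this is a limit. For the measured compounds named here, the same holds for the whole series so far: the limit of > 50100 nM in this assay, at which 2 of the 2 values shown sit.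

The next change leads to compound 3 `Cc1n[nH]c(-c2ncc3c(-c4ccccc4)ccnc3c2O)n1`: a group of 6 heavy atoms (6 carbon; one six-membered aromatic ring of carbon only) in place of a group of 8 heavy atoms (4 carbon, 1 nitrogen, 2 oxygen, 1 sulfur; one six-membered non-aromatic ring with 2 hetero atoms), on an aromatic carbon. The phenyl sits on an aromatic carbon of a six-membered aromatic ring with 1 nitrogen, opposite the ring nitrogen.

Going by the values given here, one measured step bears on this change, as it also swaps a group on an aromatic carbon: a step that the two limits leave unreadable from compound 1 to compound 2. Its size cannot be read, as both ends are limits, so it gives no size or direction to carry over. Without a readable step, the working expectation in this assay is no change beyond the scatter, and a further limit is the likeliest result. The expected step is an at least 1.1-fold lower number from compound 2 to compound 3 (0.04 log units; that floor lies within the scatter). Compound 3 is estimated at 45000 nM, with an expected range from 15000 nM to 100000 nM.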

Compound 3, half-maximal effective concentration in the THP-1 assay: > 50100 nM
Compound 3 was reported as a limit; the forecaster's own chance of this, stated with the estimate: 70%; middle value at least 1.1-fold (0.04 log units) away from the limit.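

In the THP-1 assay compound 3 gives > 50100 nM and this is a limit. For the compounds shown here, the steps to compound 3 from compound 1 and compound 2 have limits at both ends, so neither can be read and no new step results. All three compounds share one result: the limit of > 50100 nM in the THP-1 assay, at which 3 of the 3 values shown sit. Whether the three groups on this aromatic carbon differ at all in the THP-1 assay is left open by the compounds shown. In a physicochemical assay for lipophilicity, at pH 7.4 (on this read-out higher numbers stand for higher lipophilicity and lower numbers for lower lipophilicity), compound 2 gives 1.5 as its value. In the physicochemical assay compound 3 gives "not determined" (no result reported) as its entry, so no comparison between the two can be made in this read-out.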